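A few compounds are considered here, and "the series" means these few. Any claim that something is new, unique, unknown or untested is made for them only; others in the source may bear on it.

Within the data shown here, in a physicochemical assay for solubility, read by HPLC (on this read-out lower numbers stand for lower solubility and higher numbers for higher solubility), compound 1 `Nc1n[nH]c2cc(C3CCNCC3)[nH]c(=O)c12` gives 2340 ug/mL, the highest of the two numbers so far. Compound 2 `Cc1cc2[nH]nc(N)c2c(N2CCCCC2)n1` gives 794 ug/mL, a lower number by a margin beyond the scatter. Compound 3 `Cn1nc(N)c2c(=O)[nH]c(C3CCNCC3)cc21` has not yet been measured and differs from compound 1 by methyl in place of hydrogen on an aromatic nitrogen. Among the measured compounds shown here, no measured pair shows this change, so the expectation in this assay is a step within the scatter, leaning slightly toward lower numbers. The estimated step is a 1.3-fold lower number from compound 1 to compound 3 (0.11 log units; within the scatter). For compound 3 the expected value is 1800 ug/mL, with an estimated range from 800 ug/mL to 4000 ug/mL.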

Compound 3, solubility: > 15000 ug/mL
Compound 3 gave a limit, no number; the forecaster's own chance of this, stated with the estimate: 10%; at least 8.3-fold (0.92 log units) between middle value and limit.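

Among these compounds, no earlier pair carried this change, so this is the first reading of this position on the core of compound 1. In this assay, methyl in place of hydrogen on an aromatic nitrogen comes with an at least 6.4-fold higher number from compound 1 to compound 3 (0.80 log units; beyond the scatter), a step in the higher direction and beyond the scatter. Compound 3 gives a limit, not a number: the limit of > 15000 ug/mL in this assay, at which 1 of the 3 values shown sits.

The compounds shown leave open how large the step really is. They also leave open whether ethyl or a longer chain on this nitrogen would give a step in the same direction.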